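Removing Cyclopentyl from an Inactive Amide

The source may hold more compounds than are shown below. What is called first, only, known or untested is meant among the compounds shown, and "the series" means these compounds.

In a functional assay on MCF7 cells (Homo sapiens) for antiproliferative activity, read by CCK-8 assay, with a stated time of 72 h (a higher number here means a weaker inhibitor of growth, a lower number a stronger inhibitor of growth), compound 1 `CCNC(=O)c1ccc2c(ccn2-c2ncc3c(n2)N(c2ccn(C)n2)C(CC)C(=O)N3C)c1` gives 13200 nM, a weak but measurable result. Compound 2 `CCC1C(=O)N(C)c2cnc(-n3ccc4cc(C(=O)NC5CCCC5)ccc43)nc2N1c1ccn(C)n1` is reported as "not active" (no number reported), so it has no number to compare. The next structure is compound 3 `CCC1C(=O)N(C)c2cnc(-n3ccc4cc(C(N)=O)ccc43)nc2N1c1ccn(C)n1`. The change hydrogen in place of cyclopentyl on an amide-type nitrogen puts hydrogen in place of cyclopentyl on an amide-type nitrogen. Among the measured compounds shown here, with no measured step to guide it, the expected step in this assay is toward stronger inhibition, but only modest, landing near compound 1 at 13200 nM. For compound 3, the estimated value is 8000 nM, with an expected range of 1500 nM to 30000 nM.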

Compound 3, concentration for 50% growth inhibition: "not active" (no number reported)
Compound 3 has no reported number here; there is nothing to compare the estimate with.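

Compound 2 and compound 3 are both reported as not active, with no number, so no step can be read between them. Going by these compounds, whether replacing cyclopentyl with hydrogen changes growth inhibition at all stays open. No supporting evidence bears on this result.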